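The source may hold more compounds than are shown below. What is called first, only, known or untested is meant among the compounds shown, and "the series" means these compounds.

Compound 2 `Nc1scc(CN2CCN(c3c(F)cc(F)cc3F)CC2)c1C(=O)c1ccc(Cl)cc1` carries the shared core of this small set, with a 2,4,6-trifluorophenyl on the amine nitrogen of the six-membered non-aromatic ring. For the measured compounds named here, in a functional assay on CHO cells with adenosine receptor A1 (Homo sapiens) as the target, read by cAMP accumulation and immunoassay, with a stated time of 6 min, tested at 0.1 uM (a higher number here means a weaker effect of the compound at the concentration tested, a lower number a stronger effect), compound 2 gives -3.9%, the highest of the two numbers measured so far. Going by the values given here, its only neighbour is compound 1 `Nc1scc(CN2CCN(c3cc(Cl)cc(Cl)c3)CC2)c1C(=O)c1ccc(Cl)cc1`, which in this assay gives -22%; the one measured step, a number 18.1 percentage points higher from compound 1 to compound 2 (beyond the scatter), comes from swapping the ring on that nitrogen. Compound 3 `Nc1scc(CN2CCN(c3ccc(F)c(Cl)c3)CC2)c1C(=O)c1ccc(Cl)cc1` is not yet measured; it differs from compound 2 by 3-chloro-4-fluorophenyl in place of 2,4,6-trifluorophenyl on an amine nitrogen in a ring. Since compound 1 with its 3,5-dichlorophenyl sits lower than compound 2, and compound 3 brings a chlorine back onto that ring, a modest downward step is expected, a number 10.1 percentage points lower from compound 2 to compound 3 (beyond the scatter), though it may stay within the scatter. For compound 3 the estimate in this assay is -14%, ranging from -32% to 4%.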

Compound 3, a percentage reported as activity, at one concentration (the size of the read-out at that concentration, not a potency): -21%
Compound 3: middle estimate off by 7 percentage points, on the high side; measured number inside the range.
By their numbers in this assay, from the lowest: compounds 1 and 3 (each within the scatter of the next); then compound 2.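

In this assay, the change on the amine nitrogen in the ring gives a number 17.1 percentage points lower from compound 2 to compound 3 (beyond the scatter). This shows that a second replacement for the 2,4,6-trifluorophenyl also lands clearly lower. Putting 3-chloro-4-fluorophenyl in place of 3,5-dichlorophenyl gives a number 1 percentage points higher from compound 1 to compound 3 (within the scatter), so the two chlorine-bearing groups read alike here, and among these three compounds only compound 2, the one without chlorine on this ring, stands apart. Nothing available here explains this difference.

The compounds shown leave open whether chlorine itself matters or the trifluorophenyl is simply an exception, since all three rings carry halogens. A plain phenyl, or a phenyl bearing a methoxy group or a nitrile, would help separate these readings.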